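This account rests on a few compounds, and the source may have more. Where it says the series, first, only, none or still open, it means among the compounds named here.

In a functional assay on HCT-116 cells (Homo sapiens) for inhibition, read by MTT assay, with a stated time of 2 days (on this read-out lower numbers stand for stronger inhibition of growth and higher numbers for weaker inhibition of growth), compound 1 `Nc1ccccc1NC(=O)c1ccc(NCC(=O)Nc2cccc([N+](=O)[O-])c2)cc1` gives 1100 nM, the lowest of the three numbers measured. For the measured compounds named here, compound 2 `COc1ccc(NC(=O)CNCCCC(=O)Nc2ccccc2N)cc1` gives 8600 nM and compound 3 `Nc1ccccc1NC(=O)CCCNCC(=O)Nc1cc(Cl)ccc1Cl` gives 31000 nM; the only single-place step measured, a 3.6-fold higher number from compound 2 to compound 3 (0.56 log units; beyond the scatter), exchanges the group on an amide-type nitrogen of a different core. Compound 4 `COc1ccc(NC(=O)CNc2ccc(C(=O)Nc3ccccc3N)cc2)cc1` differs from compound 1 by 4-methoxyphenyl in place of 3-nitrophenyl on an amide-type nitrogen. Going by the values given here, no measured step exchanges a 3-nitrophenyl for a 4-methoxyphenyl, so that step bears on the present one only loosely, as a sign that this group can shift this assay modestly. A small rise in the number, near the edge of the scatter, is therefore expected, a 1.8-fold higher number from compound 1 to compound 4 (0.26 log units; within the scatter). Compound 4 is expected to give about 2000 nM, between 700 nM and 6000 nM.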

Compound 4, concentration for 50% growth inhibition: 7500 nM
The estimate for compound 4 lay 3.8-fold (0.57 log units) below the measured number, outside the stated range (above it).
By their numbers in this assay, from the lowest: compound 1; then compounds 4 and 2 (each within the scatter of the next); then compound 3.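

In this assay, the exchange of 3-nitrophenyl for 4-methoxyphenyl on an amide-type nitrogen is not a neutral one on the core of compound 1, as a 6.8-fold higher number from compound 1 to compound 4 (0.83 log units; beyond the scatter) shows. The group on this nitrogen therefore affects the number on this core too, and not only on the different core of compound 2. Nothing measured here bears on why the number rises.

The compounds shown leave open how a plain phenyl or a carboxylic acid in this place would compare with either group. They also cannot separate the identity of each group from where it sits on its ring.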